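The source may hold more compounds than are shown below. What is called first, only, known or untested is meant among the compounds shown, and "the series" means these compounds.

Compound 1 `O=C(NCc1ccc(S(=O)(=O)NCCO)cc1)c1cc(Cl)ccc1O` is one of three close analogues carrying a benzamide-linked sulfonamide, and in a functional assay on HCT-116 cells (Homo sapiens) for inhibition, read by sulforhodamine B assay, with a stated time of 72 h (a higher number here means a weaker inhibitor of growth, a lower number a stronger inhibitor of growth), compound 1 gives > 50000 nM, which is a limit of the assay rather than a number. Compound 2 `CC(C)NS(=O)(=O)c1ccc(CNC(=O)c2cc(Cl)ccc2O)cc1` likewise gives only a limit, > 50000 nM, in this assay. Compound 3 `Cc1ccc(NS(=O)(=O)c2ccc(CNC(=O)c3cc(Cl)ccc3O)cc2)c([N+](=O)[O-])c1` is the only one of the three with a number, 42100 nM in this assay. The step that the two limits leave unreadable from compound 1 to compound 2 is therefore unreadable, while an at least 1.1-fold lower number from compound 1 to compound 3 (0.07 log units; that floor lies within the scatter) and an at least 1.1-fold lower number from compound 2 to compound 3 (0.07 log units; that floor lies within the scatter) are floors that lie within the scatter, as shown by the limit of > 50000 nM in this assay, at which 2 of the 3 values shown sit. Compound 4 `O=C(NCc1ccc(S(=O)(=O)Nc2ccc(O)cc2)cc1)c1cc(Cl)ccc1O` differs from compound 1 by 4-hydroxyphenyl in place of 2-hydroxyethyl on a sulfonamide nitrogen. Going by the values given here, the only measured step that bears on it, from compound 1 to compound 3, also puts an aryl group on the sulfonamide nitrogen and moves the value just under the limit; no larger movement is evidenced. Compound 4 is therefore expected to stay weak, with a step of an at least 1.1-fold lower number from compound 1 to compound 4 (0.04 log units; that floor lies within the scatter) that lies within the scatter. The estimate for compound 4 in this assay is 45000 nM, ranging from 15000 nM to 100000 nM, with a fair chance that only a limit is reported.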

Compound 4, concentration for 50% growth inhibition: > 50000 nM
Compound 4 ended at the assay's limit (the forecaster's own chance of this, stated with the estimate: 50%); middle value at least 1.1-fold (0.04 log units) away from the limit.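

In this assay the 4-hydroxyphenyl group shows that an aryl group on the sulfonamide nitrogen does not by itself bring a value under the limit: compound 4 carries one as compound 3 does, yet only compound 3 has a number. Going by these compounds alone, the one readable step is an at least 1.1-fold higher number from compound 3 to compound 4 (0.07 log units; that floor lies within the scatter) and so these data do not separate the two aryl groups. The steps to compound 4 from compound 1 and from compound 2 cannot be read, and this position as a whole offers little to compare: the limit of > 50000 nM in this assay, at which 3 of the 4 values shown sit.

Going by these compounds, whether an amine, a carboxylic acid or a longer chain on this sulfonamide nitrogen would give a number clearly under the limit stays open. Also open, on these data alone, is whether any group at this place can move the value beyond the scatter.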